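Aryloxy to Benzyloxy Ether on a Shared Thiazolidinedione-Bearing Core

This account rests on a few compounds, and the source may have more. Where it says the series, first, only, none or still open, it means among the compounds named here.

In a functional assay for agonist activity at Free fatty acid receptor 1 (Homo sapiens), read by FLIPR, in the presence of a further agent that is not named here (on this read-out higher numbers stand for an effect only at larger amounts of compound and lower numbers for an effect already at smaller amounts), compound 3 `Cc1ccccc1Oc1ccc(CC2SC(=O)NC2=O)cc1` gives 124 nM, at the lower end of the three numbers. Compound 1 `Cc1cccc(Oc2ccc(CC3SC(=O)NC3=O)cc2)c1` gives 203 nM, and compound 2 `O=C1NC(=O)C(Cc2ccc(Oc3ccc(Cl)cn3)cc2)S1` gives 1870 nM. The known steps are a 1.6-fold lower number from compound 1 to compound 3 (0.21 log units; within the scatter), a 9.2-fold higher number from compound 1 to compound 2 (0.96 log units; beyond the scatter) and a 15-fold lower number from compound 2 to compound 3 (1.18 log units; beyond the scatter). Compound 4 `O=C1NC(=O)C(Cc2ccc(OCc3ccccc3)cc2)S1` differs from compound 3 in this way: benzyl in place of 2-methylphenyl on an oxygen on an aromatic ring. Going by the values given here, none of the measured steps places a benzyl group on this oxygen, so they bound the outcome only loosely: exchanging one methylphenyl for another stayed within the scatter, whereas the pyridine exchange moved the number far. A modest weakening is therefore expected, with a 2.6-fold higher number from compound 3 to compound 4 (0.41 log units; beyond the scatter) as the estimated step. Compound 4 is expected to give about 320 nM, within a range from 100 nM to 1200 nM.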

Compound 4, half-maximal effective concentration: 6180 nM
The estimate for compound 4 lay 19-fold (1.29 log units) below the measured number; measured number outside the range, above it.
By their numbers in this assay, from the lowest: compounds 3 and 1 (each within the scatter of the next); then compound 2; then compound 4.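

In this assay benzyl in place of 2-methylphenyl gives a 50-fold higher number from compound 3 to compound 4 (1.70 log units; beyond the scatter) and benzyl in place of 3-methylphenyl gives a 30-fold higher number from compound 1 to compound 4 (1.48 log units; beyond the scatter) even though the groups exchanged hold the same atoms, so on this oxygen the way those atoms are joined counts far more than the exchange of one methylphenyl for another showed. Benzyl also ranks behind 5-chloropyridin-2-yl, with a 3.3-fold higher number from compound 2 to compound 4 (0.52 log units; beyond the scatter) as the step. Nothing available here accounts for this loss. As far as these compounds go, whether a longer chain such as 2-phenylethyl on this oxygen would lose still more stays open, as does whether a methyl or chloro group on the benzyl ring would recover any of the loss.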